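Widening the carbonyl substituent from amide to urea

The source may hold more compounds than are shown below. What is called first, only, known or untested is meant among the compounds shown, and "the series" means these compounds.

Compound 1 `O=C(Nc1cccc(-n2cc(-c3ccncc3)c(-c3ccc(Cl)c(O)c3)n2)c1)Nc1ccc(Cl)c(Cl)c1`: 10900 nM
Compound 2 `COc1cc(-c2nn(-c3cccc(NC(=O)c4cccc(C(F)(F)F)c4)c3)cc2-c2ccncc2)ccc1Cl`: > 50000 nM
Compound 3 `O=C(Nc1cccc(-n2cc(-c3ccncc3)c(-c3ccc(Cl)c(O)c3)n2)c1)Nc1cc(C(F)(F)F)cc(C(F)(F)F)c1`: 2690 nM

In a functional assay on SF-268 cells (Homo sapiens) for inhibition, read by sulforhodamine B assay, with a stated time of 48 h (on this read-out higher numbers stand for weaker inhibition of growth and lower numbers for stronger inhibition of growth), compound 1 gives 10900 nM. Compound 3 gives 2690 nM. For compound 2 only a limit is known, > 50000 nM, so it stands at the weak end of the numbers shown, as noted in the limit of > 50000 nM in this assay, at which 1 of the 3 values shown sits. Among the measured compounds shown here, no pair of these three compounds differs in just one place, so no single measured step can be read from them.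

Compound 4 `COc1cc(-c2nn(-c3cccc(NC(=O)Nc4ccc(Cl)c(C(F)(F)F)c4)c3)cc2-c2ccncc2)ccc1Cl` is the unmeasured compound. It is built from compound 2 by one change: (4-chloro-3-(trifluoromethyl)phenyl)amino in place of 3-(trifluoromethyl)phenyl on a carbonyl carbon. Compound 1 and compound 3 share with compound 4 the amino group on the carbonyl carbon, and both give numbers rather than a limit in this assay. On that ground the step from compound 2 to compound 4 is expected to go toward stronger inhibition of growth, beyond the usual scatter, as an at least 6.2-fold lower number from compound 2 to compound 4 (0.79 log units; beyond the scatter). Compound 4 is therefore estimated at 8000 nM, with a range from 2000 nM to 40000 nM.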

Compound 4, concentration for total growth inhibition: 9140 nM
Estimate against measurement, compound 4: 1.1-fold (0.06 log units) below; low and high end bracket the measured number.
By their numbers in this assay, from the lowest: compound 3; then compounds 4 and 1 (each within the scatter of the next). At a limit, above all of these: compound 2.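

Compared with the earlier compounds, compound 4 gives the first reading of a single change at this position, on a carbonyl carbon whose other neighbour is an amide-type nitrogen. In this assay, putting (4-chloro-3-(trifluoromethyl)phenyl)amino in place of 3-(trifluoromethyl)phenyl gives an at least 5.4-fold lower number from compound 2 to compound 4 (0.73 log units; beyond the scatter), so this change moves growth inhibition by more than the usual scatter. For compound 2 the figure is a limit and not a measured number: the limit of > 50000 nM in this assay, at which 1 of the 4 values shown sits.

This change brings in the amino nitrogen and the chlorine together, so the compounds shown cannot tell how much of the step belongs to each. From the compounds shown here alone, it also remains open how this position would respond to an oxygen atom or a methylene group in place of the amino nitrogen.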